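The source may hold more compounds than are shown below. What is called first, only, known or untested is meant among the compounds shown, and "the series" means these compounds.

Measured compounds:
compound 1, `O=C(Nc1ccc(F)cc1)c1cncc(N2CC3CC(C2)N3)c1`, 0.01 nM
compound 2, `O=C(NCc1ccccc1)c1cncc(N2CC3CC(C2)N3)c1`, 1.8 nM
compound 3, `O=C(c1cncc(N2CC3CC(C2)N3)c1)N1CCc2ccccc2C1`, 0.031 nM

In an assay on membranes from Cerebral cortex for displacement of a labelled ligand from Neuronal acetylcholine receptor; alpha4/beta2 (Rattus norvegicus) (a lower number here means a stronger inhibitor, a higher number a weaker inhibitor), compound 2 stands at the highest number of the three: compound 3 gives 0.031 nM and compound 1 gives 0.01 nM, both well beyond the scatter below it. Among the compounds with values here, the one step that bears on the new compound is a 180-fold higher number from compound 1 to compound 2 (2.26 log units; beyond the scatter), a large rise when the aryl group on the amide nitrogen was replaced by benzyl. Compound 4, `CCc1cccc(NC(=O)c2cncc(N3CC4CC(C3)N4)c2)c1`, reverses that kind of change: 3-ethylphenyl in place of benzyl on an amide-type nitrogen. Since a direct aryl on that nitrogen went with a far lower number in compound 1 at 0.01 nM, a large drop in this assay is expected here. The step is expected to be a 36-fold lower number from compound 2 to compound 4 (1.56 log units; beyond the scatter), giving compound 4 an estimated 0.05 nM, ranging from 0.01 nM to 0.3 nM.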

Compound 4, inhibition constant: 1.3 nM
For compound 4 the middle estimate is 26-fold (1.41 log units) below the measured one; the measured number lies above the stated range.
By their numbers in this assay, from the lowest: compound 1; then compound 3; then compounds 4 and 2 (each within the scatter of the next).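

In this assay, an aryl group directly on the amide-type nitrogen does not by itself bring a very low number. Putting 3-ethylphenyl in place of benzyl gives (a 1.4-fold lower number from compound 2 to compound 4 (0.14 log units; within the scatter)), while putting it in place of 4-fluorophenyl gives (a 130-fold higher number from compound 1 to compound 4 (2.11 log units; beyond the scatter)), so the large step from benzyl to 4-fluorophenyl belongs to that particular aryl group, not to aryl groups on this nitrogen in general. No evidence is available that would explain this difference.

The compounds shown leave open whether the fluorine or the ethyl group accounts for the gap, and whether its place on the ring matters. Plain phenyl, 3-fluorophenyl and 4-ethylphenyl on this nitrogen would separate these readings.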